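Acetylation of the amino group on an isoxazole cytotoxic series

This account rests on a few compounds, and the source may have more. Where it says the series, first, only, none or still open, it means among the compounds named here.

Compound 1 `COc1cc(-c2noc(N)c2-c2ccc(Cl)cc2)cc(OC)c1OC`: > 50000 nM
Compound 2 `COc1ccc(-c2c(-c3cc(OC)c(OC)c(OC)c3)noc2NC(C)=O)cc1`: 10800 nM
Compound 3 `COc1cc(-c2noc(NC(C)=O)c2-c2ccc(Cl)cc2)cc(OC)c1OC`: 9530 nM

Of the compounds shown here, three have been measured in a functional assay on ECa-109 cells (Homo sapiens) for cytotoxicity, read by MTT assay, with a stated time of 48 h; a higher number here means a weaker inhibitor, a lower number a stronger inhibitor. Compound 1 reaches only the limit of the assay, > 50000 nM, which is a limit and not a number (the limit of > 50000 nM in this assay, at which 1 of the 3 values shown sits). Compound 3 gives 9530 nM, and compound 2 gives 10800 nM; the two differ by chloro in place of methoxy on an aromatic carbon, a step of a 1.1-fold lower number from compound 2 to compound 3 (0.05 log units; within the scatter). How the core of compound 1 differs from that of compound 2 is not broken down here.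

Compound 1 and compound 3 differ by acetyl in place of hydrogen on a nitrogen on an aromatic ring, which gives an at least 5.2-fold lower number from compound 1 to compound 3 (0.71 log units; beyond the scatter). Compound 4 `COc1ccc(-c2c(-c3cc(OC)c(OC)c(OC)c3)noc2N(C(C)=O)C(C)=O)cc1`, not yet measured, differs from compound 2 by acetyl in place of hydrogen on an amide-type nitrogen. Going by the values given here, this is the same kind of change, not the same: here the nitrogen is amide-type and its other neighbours are aromatic carbon and carbonyl carbon, whereas in compound 1 it sits on an aromatic ring with an aromatic carbon as its only other neighbour.

Compound 4 is expected to lie near compound 2, a step of a 1.1-fold lower number from compound 2 to compound 4 (0.03 log units; within the scatter), resting on compound 2 giving 10800 nM. Compound 4 is therefore estimated at 10000 nM, between 3000 nM and 40000 nM.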

Compound 4, half-maximal inhibitory concentration: 390 nM
The estimate for compound 4 lay 26-fold (1.41 log units) above the measured number; measured number below the stated range.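

Going from acetamido to diacetylamino in this assay gives a 28-fold lower number from compound 2 to compound 4 (1.44 log units; beyond the scatter), so acetyl in place of hydrogen lowers the number on the core of compound 2 as well as on the core of compound 1. This shows that the direction of the change carried over between these two cores, even though the nitrogen is amide-type in one case and not in the other, but it does not show that the size carried over, and two cores are too few to support a rule for the series: the same change on two cores in this assay, an at least 5.2-fold lower number (0.71 log units; beyond the scatter) from compound 1 to compound 3 and a 28-fold lower number (1.44 log units; beyond the scatter) from compound 2 to compound 4; the limit leaves it open whether they differ. The earlier step starts from compound 1, whose value is a limit and not a number: the limit of > 50000 nM in this assay, at which 1 of the 4 values shown sits.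

The compounds shown leave open whether the diacetylamino group would lower the number on the core of compound 3 as it does on the core of compound 2. They also leave open what a longer chain such as propionyl, or a benzoyl group, would do on the same nitrogen.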